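Vero cytotoxicity notes: exchanging the group on the saturated ring carbon

The source may report more compounds than this note shows. Statements on the series, on what has been measured and on what is new or still open speak of the compounds shown alone.

Compound 3 `CC1=C(C(=O)Nc2ccc(Cl)cc2)C(C/C=C/c2ccccc2)C(C(=O)Nc2ccc(Cl)cc2)=C(C)N1` is the reference point for this step. In an ADME assay on Vero cells (Chlorocebus sabaeus) for cytotoxicity, read by sulforhodamine B assay, with a stated time of 3 days (on this read-out lower numbers stand for higher toxicity in this test and higher numbers for lower toxicity in this test), compound 3 gives 21 ug/mL. Its two comparators are compound 1 `COc1ccc(C2C(C(=O)Nc3ccc(Cl)cc3)=C(C)NC(C)=C2C(=O)Nc2ccc(Cl)cc2)cc1`, which in this assay gives 20 ug/mL, and compound 2 `CC1=C(C(=O)Nc2ccc(Cl)cc2)C(c2cccc(Cl)c2)C(C(=O)Nc2ccc(Cl)cc2)=C(C)N1`, which in this assay gives 12 ug/mL. Both comparisons stay inside the scatter, a 1.1-fold higher number from compound 1 to compound 3 (0.02 log units; within the scatter) and a 1.8-fold higher number from compound 2 to compound 3 (0.24 log units; within the scatter), so compound 3 is not separated from either of them. The candidate is compound 4 `CC1=C(C(=O)Nc2ccc(Cl)cc2)C(c2ccccc2O)C(C(=O)Nc2ccc(Cl)cc2)=C(C)N1`, which differs by 2-hydroxyphenyl in place of 3-phenylprop-2-en-1-yl on a saturated ring carbon. Within the data shown here, three measured steps bear on this position, all exchanges at the same saturated ring carbon: a 1.7-fold lower number from compound 1 to compound 2 (0.22 log units; within the scatter), a 1.1-fold higher number from compound 1 to compound 3 (0.02 log units; within the scatter) and a 1.8-fold higher number from compound 2 to compound 3 (0.24 log units; within the scatter). None of them left the scatter, whether one aromatic substituent was exchanged for another or for the 3-phenylprop-2-en-1-yl chain. The 2-hydroxyphenyl group is therefore expected to behave like the other substituents tried there, and the step of a 1.2-fold lower number from compound 3 to compound 4 (0.09 log units; within the scatter) is expected to remain within the scatter. Compound 4 is accordingly estimated at 17 ug/mL in this assay, with a range from 8 ug/mL to 35 ug/mL.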

Compound 4, half-maximal cytotoxic concentration: 62 ug/mL
Estimate against measurement, compound 4: 3.6-fold (0.56 log units) below, and the stated range ends below it.
By their numbers in this assay, from the lowest: compounds 2, 1 and 3 (each within the scatter of the next); then compound 4.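

Among these compounds, at the saturated ring carbon, 2-hydroxyphenyl is the first group to separate from the others in this assay, with all three steps to compound 4 beyond the scatter and modest in size (a 3.0-fold higher number from compound 3 to compound 4 (0.47 log units; beyond the scatter); a 3.1-fold higher number from compound 1 to compound 4 (0.49 log units; beyond the scatter); a 5.2-fold higher number from compound 2 to compound 4 (0.71 log units; beyond the scatter)). This position is therefore not indifferent to its substituent, although 4-methoxyphenyl, 3-chlorophenyl and 3-phenylprop-2-en-1-yl remain within the scatter of one another and the change to 2-hydroxyphenyl alone moves the number towards lower toxicity in this test. No available measurement accounts for this shift.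

The compounds shown leave open whether the higher number follows the hydroxy group itself or its placement on the phenyl ring. An unsubstituted phenyl, 4-hydroxyphenyl or 2-methoxyphenyl group on this carbon would separate those two readings.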